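Difluorobenzyl swap across two amide variants

The compounds below may be only part of what the source reports. "The series", "measured", "known", "first", "only" and "open" are said of these compounds alone.

Compound 1 `CC1(C)c2[nH]nc(NC(=O)c3ccc(Br)cc3)c2CN1Cc1cccc(F)c1F` gives 950 nM in an assay on Sf21 cells for inhibition of high affinity nerve growth factor receptor (Homo sapiens), read by HTRF, with a stated time of 30 min, in the presence of a further agent that is not named here; a higher number here means a weaker inhibitor, a lower number a stronger inhibitor. Compound 2 `CC1(C)c2[nH]nc(NC(=O)c3ccc(Br)cc3)c2CN1Cc1cc(F)cc(F)c1` carries 3,5-difluorophenyl in place of 2,3-difluorophenyl on a saturated chain carbon bound to an amine nitrogen in a ring, and in this assay compound 2 gives 710 nM, so a 1.3-fold lower number from compound 1 to compound 2 (0.13 log units; within the scatter). Compound 3 `CN(C)c1cccc(C(=O)Nc2n[nH]c3c2CN(Cc2cccc(F)c2F)C3(C)C)c1` differs from compound 1 by 3-(dimethylamino)phenyl in place of 4-bromophenyl on a carbonyl carbon; in this assay compound 3 gives 420 nM, a step of a 2.3-fold lower number from compound 1 to compound 3 (0.35 log units; beyond the scatter). Compound 3 holds the lowest number of the three, though its gap to compound 2 is within the scatter.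

Compound 4 `CN(C)c1cccc(C(=O)Nc2n[nH]c3c2CN(Cc2cc(F)cc(F)c2)C3(C)C)c1` has not yet been measured. It differs from compound 3 by 3,5-difluorophenyl in place of 2,3-difluorophenyl on a saturated chain carbon bound to an amine nitrogen in a ring, which is the same change as that from compound 1 to compound 2, made at the same place; the two cores differ by 3-(dimethylamino)phenyl in place of 4-bromophenyl on a carbonyl carbon. The change occurs twice among these compounds, and the one measured instance was within the scatter.

The step from compound 3 to compound 4 in this assay is expected to be small, about a 1.2-fold lower number from compound 3 to compound 4 (0.09 log units; within the scatter), because the same change gave a 1.3-fold lower number from compound 1 to compound 2 (0.13 log units; within the scatter) in the first pair. Compound 4 is estimated at 340 nM, with a likely range from 170 nM to 700 nM.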

Compound 4, half-maximal inhibitory concentration: 270 nM
Beside the measured number, compound 4's estimate is 1.3-fold (0.10 log units) above it; measured number inside the range.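

In this assay, the change from 2,3-difluorobenzyl to 3,5-difluorobenzyl gives a 1.6-fold lower number from compound 3 to compound 4 (0.19 log units; within the scatter), and the two instances of this change agree: the same change on two cores in this assay, a 1.3-fold lower number (0.13 log units; within the scatter) from compound 1 to compound 2 and a 1.6-fold lower number (0.19 log units; within the scatter) from compound 3 to compound 4, 1.2-fold (0.07 log units) apart, within the scatter of two such steps

The amide change, 3-(dimethylamino)phenyl in place of 4-bromophenyl on a carbonyl carbon, gives a 2.6-fold lower number from compound 2 to compound 4 (0.42 log units; beyond the scatter), and it also carries over, here between the two difluorobenzyl variants: the same change on two cores in this assay, a 2.3-fold lower number (0.35 log units; beyond the scatter) from compound 1 to compound 3 and a 2.6-fold lower number (0.42 log units; beyond the scatter) from compound 2 to compound 4, 1.2-fold (0.07 log units) apart, within the scatter of two such steps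

Within these four compounds the two changes therefore behave as independent of each other, but this rests on only two pairs for each change, the difluorobenzyl step stays within the scatter on both cores, and nothing here shows that the agreement extends to other amide or benzyl groups.

Still open, as far as these compounds go, is whether the same independence holds with a morpholine or a carboxylic acid in place of the dimethylamino group. Also open, from the compounds shown here alone, is how an unsubstituted benzyl or a longer chain would read in place of the difluorobenzyl groups.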